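The source may hold more compounds than are shown below. What is called first, only, known or untested is meant among the compounds shown, and "the series" means these compounds.

Compound 1 `Cc1cc(Br)c(S(C)(=O)=O)cc1C(=O)N=C(N)N`, compound 2 `Cc1cc(C)c(S(C)(=O)=O)cc1C(=O)N=C(N)N` and compound 3 `Cc1cc(C2CCCCC2)c(S(C)(=O)=O)cc1C(=O)N=C(N)N` share one core and differ only in the group ortho to the methylsulfonyl group. In a functional assay for inhibition of sodium/hydrogen exchanger (Oryctolagus cuniculus) (a lower number here means a stronger inhibitor, a higher number a weaker inhibitor), compound 1 gives 12 nM, compound 2 gives 11 nM and compound 3 gives 22 nM. Compound 3 is separated from compound 1 by a 1.8-fold higher number from compound 1 to compound 3 (0.26 log units; within the scatter) and from compound 2 by a 2.0-fold higher number from compound 2 to compound 3 (0.30 log units; within the scatter); the remaining pair shows a 1.1-fold lower number from compound 1 to compound 2 (0.04 log units; within the scatter), so none of the three steps leaves the scatter. Compound 4 `Cc1cc(-c2cc(Cl)cc(Cl)c2)c(S(C)(=O)=O)cc1C(=O)N=C(N)N` is unmeasured; the change is 3,5-dichlorophenyl in place of cyclohexyl on an aromatic carbon. Both earlier exchanges at this place, bromo or methyl to cyclohexyl, were within the scatter, so no step beyond the scatter is expected in this assay, about a 1.1-fold higher number from compound 3 to compound 4 (0.06 log units; within the scatter). Compound 4 is estimated at 25 nM, within 8 nM to 80 nM.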

Compound 4, half-maximal inhibitory concentration: 130 nM
For compound 4 the middle estimate is 5.2-fold (0.72 log units) below the measured one; measured number above the stated range.
By their numbers in this assay, from the lowest: compounds 2, 1 and 3 (each within the scatter of the next); then compound 4.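

In this assay the place ortho to a methylsulfonyl group proves sensitive to its substituent: 3,5-dichlorophenyl gives a 5.9-fold higher number from compound 3 to compound 4 (0.77 log units; beyond the scatter) and also a 12-fold higher number from compound 2 to compound 4 (1.07 log units; beyond the scatter) and an 11-fold higher number from compound 1 to compound 4 (1.03 log units; beyond the scatter) as steps beyond the scatter. Bromo, methyl and cyclohexyl remain within the scatter of one another, so tolerance here does not extend to every six-membered ring. Nothing available bears on the reason for this step. The compounds shown leave open whether the aromatic ring or the two chlorines account for the step. As far as these compounds go, a plain phenyl would separate the two, and an amine or carboxylic acid on that ring remains unexplored here.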